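Chain extension on the shared aryl urea core: compound 4

The source may report more compounds than this note shows. Statements on the series, on what has been measured and on what is new or still open speak of the compounds shown alone.

Compound 1 `Cc1ccc(NC(=O)N[C@H](C)c2ccccc2)cc1`, compound 2 `CCc1ccc(NC(=O)N[C@H](C)c2ccccc2)cc1` and compound 3 `CCCCc1ccc(NC(=O)N[C@H](C)c2ccccc2)cc1` share one core and differ only in the saturated chain bound to one aromatic carbon. In an ADME assay on the whole organism with Oryza sativa as the target, tested at 0.1 uM (on this read-out higher numbers stand for a weaker effect at the one concentration tested and lower numbers for a stronger effect), compound 1 gives 100%, compound 2 gives 95% and compound 3 gives 100%. Compound 3 stands level with compound 1 at the digits shown, the two together the highest of the three numbers, with compound 2 the furthest from it; none of the three values lies beyond the scatter of another.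

The measured steps are all small: a number 5 percentage points lower from compound 1 to compound 2 (within the scatter), no change at the digits printed from compound 1 to compound 3 (within the scatter) and a number 5 percentage points higher from compound 2 to compound 3 (within the scatter). Each of them lengthens the same chain on the same aromatic carbon, and none moves the read-out beyond the scatter.

Compound 4 `CCCCCCCc1ccc(NC(=O)N[C@H](C)c2ccccc2)cc1` continues that chain: propyl in place of hydrogen on a saturated chain carbon, four bonds along the chain from an aromatic carbon. All three measured steps bear on this change and all stayed within the scatter, so in this assay no movement beyond the scatter is expected, and the step is estimated as a number 1 percentage points lower from compound 3 to compound 4 (within the scatter). Compound 4 is accordingly expected to give about 99%, with a range from 88% to 106%.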

Compound 4, a percentage reported as activity, at one concentration (the size of the read-out at that concentration, not a potency): 100%
Beside the measured number, compound 4's estimate is 1 percentage points below it; the measured number falls inside the stated range.
By their numbers in this assay, from the lowest: compounds 2, 1, 3 and 4 (each within the scatter of the next).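

Taking the chain further out on the shared core, propyl in place of hydrogen on a saturated chain carbon, four bonds along the chain from an aromatic carbon, gives in this assay no change at the digits printed from compound 3 to compound 4 (within the scatter). Going by these compounds alone, the larger replacements read the same way, with the longer chain of the two giving a number 5 percentage points higher from compound 2 to compound 4 (within the scatter), and the longest replacement giving no change at the digits printed from compound 1 to compound 4 (within the scatter), so the absence of any step beyond the scatter now reaches a longer chain than the earlier compounds covered, with none of compound 1, compound 2, compound 3 or compound 4 going against it. No evidence is available on why this read-out stays within the scatter along the series.

As far as these compounds go, whether a longer chain than that of compound 4, or a chain carrying an amine or a carboxylic acid, would move the number beyond the scatter remains open. From the compounds shown here alone, all four compounds keep the rest of the shared core unchanged, so the effect of a change elsewhere in this assay also stays open, as does any reading at a different concentration.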